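This account rests on a few compounds, and the source may have more. Where it says the series, first, only, none or still open, it means among the compounds named here.

In an assay on CHO cells for displacement of a labelled ligand from 5-hydroxytryptamine receptor 7 (Homo sapiens) (a lower number here means a stronger inhibitor, a higher number a weaker inhibitor), compound 1 `CCC1(CCCCN2CCN(c3ccccc3OC)CC2)C(=O)Nc2ccccc21` gives 5.38 nM, while compound 2 `CCC1(CCCCN2CCN(c3ccc(Cl)cc3)CC2)C(=O)Nc2c(Cl)cc(F)cc21` gives 5.97 nM; these two numbers sit within the scatter of each other, so compound 1 does not stand apart from compound 2 on what has been measured. Compound 3 `CCC1(CCCCN2CCN(c3ccc(C)c(Cl)c3)CC2)C(=O)Nc2ccccc21` differs from compound 1 in one place: 3-chloro-4-methylphenyl in place of 2-methoxyphenyl on an amine nitrogen in a ring. Within the data shown here, no measured pair isolates this change, so the size of its effect is unknown. The expected step of a 1.7-fold higher number from compound 1 to compound 3 (0.22 log units; within the scatter) is small, at most a little beyond the scatter, toward a weaker inhibitor. Compound 3 is expected to give about 9 nM in this assay, estimated between 3 nM and 30 nM.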

Compound 3, inhibition constant: 0.66 nM
Compound 3: the middle estimate sits 14-fold (1.13 log units) above what was measured, and the stated range ends above it.
By their numbers in this assay, from the lowest: compound 3; then compounds 1 and 2 (each within the scatter of the next).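

In this assay, the group on the amine nitrogen of the six-membered ring with 2 nitrogen clearly matters: 3-chloro-4-methylphenyl in place of 2-methoxyphenyl gives an 8.2-fold lower number from compound 1 to compound 3 (0.91 log units; beyond the scatter) in a single change, a step beyond the scatter. Compound 1 and compound 2 differ in more than one place, so they could not isolate this position. Nothing at hand explains the size of this step. Still open, as far as these compounds go, is whether the chlorine, the methyl or the loss of the methoxy group drives the step. A plain phenyl or a pyridyl group at this position would help separate these contributions.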